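A few compounds are considered here, and "the series" means these few. Any claim that something is new, unique, unknown or untested is made for them only; others in the source may bear on it.

Among the measured compounds shown here, compound 2 `O=C(/C=C/CCc1ccccc1)c1ccccc1F` gives 1760 nM in a functional assay on HEK293 cells for antagonist activity at G-protein coupled receptor 52 (Homo sapiens), read by cAMP accumulation, with stated times of 15 min and 30 min (on this read-out higher numbers stand for weaker inhibition and lower numbers for stronger inhibition), one of only two numbers measured so far; the other belongs to compound 1 `COc1ccccc1C(=O)/C=C/CCc1ccccc1`, which gives 1720 nM and lies within the scatter of it, as the step of a 1.0-fold higher number from compound 1 to compound 2 (0.01 log units; within the scatter) shows. Compound 3 `O=C(/C=C/CCc1ccccc1)c1ccccc1-c1ccccc1` differs from compound 2 by phenyl in place of fluoro on an aromatic carbon. For the measured compounds named here, the single measured step concerns a different exchange at that carbon and stayed within the scatter, so nothing measured speaks directly to a phenyl entering there; the step expected in this assay is therefore a 1.0-fold lower number from compound 2 to compound 3 (0.02 log units; within the scatter), none beyond the scatter. Compound 3 is expected to give about 1700 nM, between 500 nM and 6000 nM.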

Compound 3, half-maximal inhibitory concentration: 1230 nM
Compound 3: middle estimate off by 1.4-fold (0.14 log units), on the high side; the measured number falls inside the stated range.
By their numbers in this assay, from the lowest: compounds 3, 1 and 2 (each within the scatter of the next).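

At this aromatic carbon, ortho to a large group, phenyl, with its six heavy atoms and six-membered aromatic ring, can replace fluoro (a 1.4-fold lower number from compound 2 to compound 3 (0.16 log units; within the scatter)) or methoxy (a 1.4-fold lower number from compound 1 to compound 3 (0.15 log units; within the scatter)) with the number in this assay staying within the scatter. Groups as different as these three have so far left this read-out unmoved at this carbon. Nothing measured explains this. Still open, from the compounds shown here alone, is whether an amine or a carboxylic acid at this carbon would move the number beyond the scatter, and whether a longer chain elsewhere on the shared core would do so.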